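Methoxyphenyl positional change on the shared core

A few compounds are considered here, and "the series" means these few. Any claim that something is new, unique, unknown or untested is made for them only; others in the source may bear on it.

Measured so far:
compound 1 `N[C@H]1CC[C@H](Nc2nc(Nc3ccc(-c4cccs4)nc3)c3ncn(C4CCCC4)c3n2)CC1` gives 574 nM in a functional assay on K562 cells (Homo sapiens) for inhibition, read by fluorescence and resazurin assay, with a stated time of 72 h; on this read-out higher numbers stand for weaker inhibition of growth and lower numbers for stronger inhibition of growth
compound 2 `COc1ccccc1-c1ccc(Nc2nc(N[C@H]3CC[C@H](N)CC3)nc3c2ncn3C2CCCC2)cn1` gives 553 nM in this assay

Compound 2 holds the lower of the two numbers, but its gap to compound 1, a 1.0-fold lower number from compound 1 to compound 2 (0.02 log units; within the scatter), is within the scatter. Compound 3 `COc1ccc(-c2ccc(Nc3nc(N[C@H]4CC[C@H](N)CC4)nc4c3ncn4C3CCCC3)cn2)cc1` differs from compound 2 by 4-methoxyphenyl in place of 2-methoxyphenyl on an aromatic carbon. Among the measured compounds shown here, no measured step covers this change; the only step, a 1.0-fold lower number from compound 1 to compound 2 (0.02 log units; within the scatter), concerns a different exchange and was within the scatter. Compound 3 is therefore expected to give about 600 nM (range 250 nM to 1400 nM) in this assay, an expected step of a 1.1-fold higher number from compound 2 to compound 3 (0.04 log units; within the scatter) no larger than the scatter.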

Compound 3, concentration for 50% growth inhibition: 698 nM
For compound 3 the middle estimate is 1.2-fold (0.07 log units) below the measured one; measured number inside the range.
By their numbers in this assay, from the lowest: compounds 2, 1 and 3 (each within the scatter of the next).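

On this aromatic carbon, next to the ring nitrogen, moving the methoxy group around the phenyl ring leaves the number in this assay within the scatter (a 1.3-fold higher number from compound 2 to compound 3 (0.10 log units; within the scatter)). Exchanging thiophen-2-yl for 4-methoxyphenyl is likewise within the scatter (a 1.2-fold higher number from compound 1 to compound 3 (0.08 log units; within the scatter)), so the three groups cannot be told apart here. No independent measurement bears on this result. Still open, as far as these compounds go, is whether a carboxylic acid or an amine on the phenyl ring at this position would move the number beyond the scatter.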